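The source may report more compounds than this note shows. Statements on the series, on what has been measured and on what is new or still open speak of the compounds shown alone.

Of the compounds shown here, three built on one shared core have been measured in an assay on membranes from CHO cells for displacement of a labelled ligand from adenosine receptor A1 (Homo sapiens), read by scintillation counting, with a stated time of 60 min, tested at 1 uM; a higher number here means more inhibition at the concentration tested (going by the name of the read-out), a lower number less inhibition. Compound 1 `CC1=C(C(=O)C2CC2)C(c2ccoc2)NC(=O)N1` gives 1%, compound 2 `CC1=C(C(N)=O)C(c2ccoc2)NC(=O)N1` gives 1%, and compound 3 `CC1=C(C(N)=O)C(c2ccsc2)NC(=O)N1` gives 2%. Compound 2 thus stands level with compound 1 at the digits shown, the two together the lowest of the three numbers, while the step of a number 1 percentage points higher from compound 2 to compound 3 (within the scatter) stays within the scatter. Compound 4 `CC1=C(C(=O)OC2CCCC2)C(c2ccoc2)NC(=O)N1` has not yet been measured; it differs from compound 2 by cyclopentyloxy in place of amino on a carbonyl carbon. Going by the values given here, the only measured step at that carbonyl carbon, no change at the digits printed from compound 1 to compound 2 (within the scatter), moved nothing beyond the scatter. The step to compound 4 is therefore expected to be a number 1 percentage points higher from compound 2 to compound 4 (within the scatter). For compound 4 a value of 2% is estimated, in a range from -6% to 12%.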

Compound 4, a percentage reported as inhibition, at one concentration (the size of the read-out at that concentration, not a potency): 6%
Beside the measured number, compound 4's estimate is 4 percentage points below it; measured number inside the range.
By their numbers in this assay, from the lowest: compounds 1, 2, 3 and 4 (each within the scatter of the next).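

In this assay, cyclopentyloxy on the carbonyl carbon gives a number 5 percentage points higher from compound 2 to compound 4 (within the scatter) and, set against the cyclopropyl group, a number 5 percentage points higher from compound 1 to compound 4 (within the scatter). Amino, cyclopropyl and the ring-bearing cyclopentyloxy group therefore all leave this read-out within the scatter at the one concentration tested, so even this larger change at the position separates none of these compounds. Nothing available here offers an explanation for these numbers. Still open, as far as these compounds go, is whether a carboxylic acid or a longer chain on this carbonyl carbon would move the number beyond the scatter.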